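Swapping the Aryl Group on a Triazole-Linked Lactam

The source may report more compounds than this note shows. Statements on the series, on what has been measured and on what is new or still open speak of the compounds shown alone.

Three compounds have been tested in a functional assay on A549 cells (Homo sapiens) for inhibition, read by MTT assay, with a stated time of 24 h; a lower number here means a stronger inhibitor, a higher number a weaker inhibitor:

Compound 1 `Cc1ccccc1-n1cc(CN2C(=O)C[C@@H]3CC[C@@]2(C)C3(C)C)nn1` gives 90 nM
Compound 2 `COc1ccccc1-n1cc(CN2C(=O)C[C@@H]3CC[C@@]2(C)C3(C)C)nn1` gives 350 nM
Compound 3 `CC1(C)[C@H]2CC[C@]1(C)N(Cc1cn(-c3cccc(O)c3)nn1)C(=O)C2` gives 180 nM

Compound 1 stands at the low end of the three: a 3.9-fold higher number from compound 1 to compound 2 (0.59 log units; beyond the scatter) is beyond the scatter, but a 2.0-fold higher number from compound 1 to compound 3 (0.30 log units; within the scatter) is within it, so compound 1 and compound 3 cannot be ranked against each other.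

Compound 4 `CC1(C)[C@H]2CC[C@]1(C)N(Cc1cn(-c3cccc(Br)c3)nn1)C(=O)C2` differs from compound 1 by 3-bromophenyl in place of 2-methylphenyl on an aromatic nitrogen. The step that bears most on this is a 2.0-fold higher number from compound 1 to compound 3 (0.30 log units; within the scatter), another exchange of the aryl group on the aromatic nitrogen, which stayed within the scatter; a 1.9-fold lower number from compound 2 to compound 3 (0.29 log units; within the scatter) did likewise. Such exchanges have so far moved the number little, so compound 4 is expected to land near compound 1, with a step of about a 1.3-fold higher number from compound 1 to compound 4 (0.12 log units; within the scatter). Compound 4 is therefore estimated at 120 nM, within a range of 50 nM to 300 nM.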

Compound 4, half-maximal inhibitory concentration: 90 nM
For compound 4 the middle estimate is 1.3-fold (0.12 log units) above the measured one; the range from low to high includes it.
By their numbers in this assay, from the lowest: compounds 1, 4, 3 and 2 (each within the scatter of the next, the first and the last beyond it).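

Putting 3-bromophenyl on the aromatic nitrogen in place of 2-methylphenyl leaves the number where it was (no change at the digits printed from compound 1 to compound 4 (within the scatter)), so this position accepts either aryl group here. Bromo in place of hydroxy on the aromatic carbon gives no step that can be ranked (a 2.0-fold lower number from compound 3 to compound 4 (0.30 log units; within the scatter)), whereas 3-bromophenyl in place of 2-methoxyphenyl gives a step beyond the scatter (a 3.9-fold lower number from compound 2 to compound 4 (0.59 log units; beyond the scatter)). Nothing measured here accounts for these steps.

From the compounds shown here alone, whether an amine or a carboxylic acid on the aryl ring would keep the number in this range remains open. So does the effect of a longer chain in place of the aryl group.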